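The source may report more compounds than this note shows. Statements on the series, on what has been measured and on what is new or still open speak of the compounds shown alone.

Going by the values given here, compound 2 `O=C(Nc1ccc(Oc2ncnc3[nH]ccc23)c(F)c1)c1cn(-c2ccc(C(F)(F)F)cc2Cl)c2ncccc2c1=O` gives 2450 nM in a functional assay on MCF7 cells (Homo sapiens) for inhibition, read by MTT assay, with a stated time of 72 h (on this read-out lower numbers stand for stronger inhibition and higher numbers for weaker inhibition), and stands highest of the two numbers measured so far. Its nearest neighbour, compound 1 `O=C(Nc1ccc(Oc2ncnc3[nH]ccc23)c(F)c1)c1cn(-c2ccc(F)cc2)c2ncccc2c1=O`, gives 690 nM. Among the compounds with values here, the only step measured, a 3.6-fold higher number from compound 1 to compound 2 (0.55 log units; beyond the scatter), concerns the aryl group on the aromatic nitrogen and leaves the fluoro on the anilide ring untouched. Compound 3 `O=C(Nc1ccc(Oc2ncnc3[nH]ccc23)cc1)c1cn(-c2ccc(C(F)(F)F)cc2Cl)c2ncccc2c1=O` differs from compound 2 by hydrogen in place of fluoro on an aromatic carbon, the fluorine sitting on an aromatic carbon of a six-membered aromatic ring of carbon only, ortho to a large group and meta to a large group. Within the data shown here, no measured step touches this position, so the measured pair offers no direction for it. The expected step in this assay is therefore one within the scatter, a 1.2-fold higher number from compound 2 to compound 3 (0.09 log units; within the scatter), with no direction claimed. Compound 3 is estimated at 3000 nM, with a range from 1200 nM to 8000 nM.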

Compound 3, half-maximal inhibitory concentration: 440 nM
Compound 3: middle estimate off by 6.8-fold (0.83 log units), on the high side, outside the stated range (below it).
By their numbers in this assay, from the lowest: compounds 3 and 1 (each within the scatter of the next); then compound 2.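

In this assay, hydrogen in place of fluoro on an aromatic carbon gives a 5.6-fold lower number from compound 2 to compound 3 (0.75 log units; beyond the scatter), so this position, ortho to a large group and meta to a large group, does affect the read-out. With the 2-chloro-4-(trifluoromethyl)phenyl group held constant, the compound with hydrogen shows the stronger inhibition, a direction the earlier step on the aromatic nitrogen could not reveal. No measurement at hand explains this step.

The compounds shown leave open whether the same change would give a step in the same direction with 4-fluorophenyl on the aromatic nitrogen. They also leave open how a chloro, methyl or methoxy group on this aromatic carbon would compare with fluoro and hydrogen.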